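The source may report more compounds than this note shows. Statements on the series, on what has been measured and on what is new or still open speak of the compounds shown alone.

The series rests on compound 1 `CC(C)[C@H](NC(=O)COc1cccc2ccccc12)C(=O)N[C@@H](CC(=O)O)C(=O)COc1ccccc1`, which gives 14000 nM in a functional assay on Jurkat cells (Homo sapiens); on this read-out lower numbers stand for stronger inhibition and higher numbers for weaker inhibition. With a cyano group on the aromatic ring, compound 2 `CC(C)[C@H](NC(=O)COc1cccc2ccccc12)C(=O)N[C@@H](CC(=O)O)C(=O)COc1ccc(C#N)cc1` gives > 100000 nM, which is a limit of the assay and not a number. With a nitro group, compound 3 `CC(C)[C@H](NC(=O)COc1cccc2ccccc12)C(=O)N[C@@H](CC(=O)O)C(=O)COc1ccccc1[N+](=O)[O-]` gives > 100000 nM, which is also only a limit. Compound 3 thus stands at the limit of > 100000 nM in this assay, at which 2 of the 3 values shown sit. The measured record shows an at least 7.1-fold higher number from compound 1 to compound 2 (0.85 log units; beyond the scatter) and an at least 7.1-fold higher number from compound 1 to compound 3 (0.85 log units; beyond the scatter), while the comparison of the two limits gives a step that the two limits leave unreadable from compound 2 to compound 3.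

Compound 4 `CC(C)[C@H](NC(=O)COc1cccc2ccccc12)C(=O)N[C@@H](CC(=O)O)C(=O)COc1c(F)cccc1F` differs from compound 3 in one place: 2,6-difluorophenyl in place of 2-nitrophenyl on an oxygen on a saturated carbon. In words, this is 2,6-difluorophenyl in place of 2-nitrophenyl on an oxygen on a saturated carbon. The nitro group leaves, so the closest guide is the reverse of an at least 7.1-fold higher number from compound 1 to compound 3 (0.85 log units; beyond the scatter), which points back towards compound 1. Compound 4 still carries added groups on its ring, however, and compound 2 warns against a full return with an at least 7.1-fold higher number from compound 1 to compound 2 (0.85 log units; beyond the scatter). For the measured compounds named here, no measured step involves fluorine. A lower number in this assay, beyond the scatter, is therefore expected. The expected change is an at least 16-fold lower number from compound 3 to compound 4 (1.22 log units; beyond the scatter). For compound 4, the estimated value is 6000 nM, with an expected range of 700 nM to 45000 nM.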

Compound 4, half-maximal inhibitory concentration: 2040 nM
Beside the measured number, compound 4's estimate is 2.9-fold (0.47 log units) above it; measured number inside the range.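

For the compounds shown here, compound 4 is the first compound with added groups on the phenyl ring to give a number rather than a limit in this assay, and the change to 2,6-difluorophenyl yields an at least 49-fold lower number from compound 3 to compound 4 (1.69 log units; beyond the scatter) and an at least 49-fold lower number from compound 2 to compound 4 (1.69 log units; beyond the scatter). Added groups on this ring, which sits on an oxygen on a saturated carbon, therefore do not always raise the number, and here the change from the unsubstituted phenyl goes the other way: a 6.9-fold lower number from compound 1 to compound 4 (0.84 log units; beyond the scatter). The two larger steps are minimum sizes, since compound 2 and compound 3 each give a limit of the assay and not a number: the limit of > 100000 nM in this assay, at which 2 of the 4 values shown sit.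

Going by these compounds, whether a single fluorine would give part of this change or all of it remains open, as does whether chlorine or a methyl group in place of the two fluorines would give a similar number. On these data alone, how far compound 2 and compound 3 actually lie from compound 4 also stays unknown, and the step between compound 2 and compound 3 cannot be read.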